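Trimethoxyphenyl oxadiazoline and hydrazone analogues: antiproliferative screen

The source may report more compounds than this note shows. Statements on the series, on what has been measured and on what is new or still open speak of the compounds shown alone.

Measured so far:
compound 1 `COc1cc(C2=NN(C(C)=O)C(c3cc(Cl)cc(Cl)c3)O2)cc(OC)c1OC`: 6.6%
compound 2 `COc1cc(C(=O)N/N=C/c2ccc(C(F)(F)F)cc2)cc(OC)c1OC`: 56.3%
compound 3 `COc1cc(/C=N/NC(=O)c2cc(OC)c(OC)c(OC)c2)cc(OC)c1OC`: 22.9%

In a functional assay on BGC-823 cells (Homo sapiens) for antiproliferative activity, read by MTT assay, tested at 5 uM (a higher number here means a stronger effect of the compound at the concentration tested, a lower number a weaker effect), compound 1 gives 6.6%, the lowest of the three numbers. Compound 3 stands beyond the scatter above it, compound 2 further still; the two hydrazones thus sit well above the acetylated oxadiazoline of compound 1.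

Compound 4 `COc1cc(C2=NN(C(C)=O)C(c3ccc(Cl)c([N+](=O)[O-])c3)O2)cc(OC)c1OC` is the next member. It differs from compound 1 by 4-chloro-3-nitrophenyl in place of 3,5-dichlorophenyl on a saturated ring carbon. For the measured compounds named here, no pair of measured compounds shows this kind of change, so there is nothing to say of its usual size. Compound 4 is expected to stay near compound 1, with a step of a number 3.4 percentage points higher from compound 1 to compound 4 (within the scatter) not beyond the scatter. Compound 4 is estimated at 10%, within 1% to 28%.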

Compound 4, a percentage reported as inhibition, at one concentration (the size of the read-out at that concentration, not a potency): 0%
Compound 4: the middle estimate sits 10 percentage points above what was measured, outside the stated range (below it).
By their numbers in this assay, from the lowest: compounds 4 and 1 (each within the scatter of the next); then compound 3; then compound 2.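

In this assay, 4-chloro-3-nitrophenyl in place of 3,5-dichlorophenyl on the saturated ring carbon gives a number 6.6 percentage points lower from compound 1 to compound 4 (within the scatter) and so does not separate the two compounds. At this position, then, the exchange of one chlorine pair for a chlorine and nitro pattern has no readable effect on the acetylated core. Nothing measured here gives a reason for the size of this step.

On these data alone, whether an amine or a carboxylic acid on this phenyl ring would move the read-out remains open. So does the effect of replacing the acetyl group with a longer chain.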